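A few compounds are considered here, and "the series" means these few. Any claim that something is new, unique, unknown or untested is made for them only; others in the source may bear on it.

Measured compounds:

- compound 1, `O=C1/C(=C/c2ccc(Cl)c(Cl)c2)CCCc2ccccc21`, 11800 nM
- compound 2, `O=C1/C(=C/c2ccccc2F)Cc2ccccc21`, 47100 nM
- compound 3, `O=C1/C(=C/c2ccccc2Cl)CCCc2ccccc21`, 18400 nM

All three were tested in a functional assay on CCRF-CEM cells (Homo sapiens) for inhibition; on this read-out higher numbers stand for weaker inhibition and lower numbers for stronger inhibition. Compound 2 stands at the top of the three numbers: its value is beyond the usual scatter away from compound 3, which gives 18400 nM, and further still from compound 1, which gives 11800 nM. Compound 2 is thus the weakest inhibitor of the three in this assay.

Compound 4, `Cc1ccccc1/C=C1\Cc2ccccc2C1=O`, has not yet been measured. It differs from compound 2 in one place: methyl in place of fluoro on an aromatic carbon. Going by the values given here, no measured pair in this set shows what such a swap does, so there is no direct guide. A change of one heavy atom for another, with no ring, donor or acceptor gained or lost, would more often than not leave a value close to where it started, so a step no larger than the scatter in either direction is the likeliest outcome, with a modest move toward stronger inhibition somewhat more plausible than the reverse.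

For compound 4 the expected value in this assay is 38000 nM, with a range from 14000 nM to 100000 nM. This corresponds to an expected step of a 1.2-fold lower number from compound 2 to compound 4 (0.09 log units; within the scatter).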

Compound 4, half-maximal inhibitory concentration: 56500 nM
Beside the measured number, compound 4's estimate is 1.5-fold (0.17 log units) below it, within the range that was stated.
By their numbers in this assay, from the lowest: compounds 1 and 3 (each within the scatter of the next); then compounds 2 and 4 (each within the scatter of the next).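

Putting methyl in place of fluoro on this aromatic carbon, ortho to a large group, gives a 1.2-fold higher number from compound 2 to compound 4 (0.08 log units; within the scatter) in this assay. Going by these compounds alone, this is the first pair in the set to differ in one place only, and it shows that this swap of one heavy atom for another leaves the read-out unchanged within normal measurement variation, so the two groups cannot be told apart here. No measured evidence is available to explain this result.

Still open, going by these compounds, is whether a group of a different kind at this place, such as an amine, a carboxylic acid or a longer chain, would move the number beyond the scatter. Also open, on these data alone, is whether methyl in place of the chloro group of compound 3, on its larger core, would give an equally small step.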